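Chloro at the phenoxy ring of a triazole series

This account rests on a few compounds, and the source may have more. Where it says the series, first, only, none or still open, it means among the compounds named here.

Measured so far in an assay on isolated protein for inhibition of Aromatase (Homo sapiens), read by fluorescence and colorimetric assay, with a stated time of 30 min; a lower number here means a stronger inhibitor, a higher number a weaker inhibitor:
compound 1 `CCCCCCCc1cn(C(c2ccccc2)c2ccccc2)nn1` gives 19400 nM;
compound 2 `c1ccc(OCc2cn(C(c3ccccc3)c3ccccc3)nn2)cc1` gives 31300 nM.

Within the data shown here, compound 2 stands at the higher of the two numbers, with compound 1 its only neighbour; the step of a 1.6-fold higher number from compound 1 to compound 2 (0.21 log units; within the scatter) lies within the scatter, so the two compounds cannot be ordered against each other in this assay.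

Compound 3 `Clc1ccc(OCc2cn(C(c3ccccc3)c3ccccc3)nn2)cc1` is the next member. Against compound 2 the change is chloro in place of hydrogen on an aromatic carbon; read one bond further out, phenoxy becomes 4-chlorophenoxy. Among the measured compounds shown here, no measured step touches this position: the only step known, from compound 1 to compound 2, exchanges the whole hexyl for phenoxy and says nothing about a substituent on the phenoxy ring. The expectation therefore rests on the small size of that one step and on the size of the change itself.

A step of about a 1.4-fold lower number from compound 2 to compound 3 (0.15 log units; within the scatter) from compound 2 is expected, that is, no shift beyond the scatter in this assay. Compound 3 is estimated at 22000 nM, with a range from 8000 nM to 60000 nM.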

Compound 3, half-maximal inhibitory concentration: 13400 nM
Compound 3: the middle estimate sits 1.6-fold (0.22 log units) above what was measured, and the stated range covers the measured number.
By their numbers in this assay, from the lowest: compounds 3, 1 and 2 (each within the scatter of the next, the first and the last beyond it).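

Among these compounds, with a 2.3-fold lower number from compound 2 to compound 3 (0.37 log units; beyond the scatter) in this assay, this is the first step that lies beyond the scatter, and it is modest in size. The earlier exchange of hexyl for phenoxy gave no readable shift, whereas a single chloro on an aromatic carbon of the phenoxy ring, para to a large group, does separate compound 3 from compound 2. The gain in separation stops there: with a 1.4-fold lower number from compound 1 to compound 3 (0.16 log units; within the scatter), 4-chlorophenoxy and hexyl cannot be ordered against each other, so the chloro does not set compound 3 apart from compound 1, and no measurement shown accounts for the shift produced by the chloro.

Open, on these data alone, is whether the step belongs to chloro itself or would recur with fluoro, methoxy or an amine on the same aromatic carbon, and whether chloro elsewhere on the phenoxy ring would give a step of like size. Also open, as far as these compounds go, is how a longer chain or a carboxylic acid in place of 4-chlorophenoxy would stand against compound 3 on the shared core.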